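The source may report more compounds than this note shows. Statements on the series, on what has been measured and on what is new or still open speak of the compounds shown alone.

Of the compounds shown here, two have so far been measured in an assay on HEK293 cells for displacement of a labelled ligand from Melanocortin receptor 4 (Homo sapiens); a higher number here means a weaker inhibitor, a lower number a stronger inhibitor. Compound 1 `CC(C)[C@H](NC(=O)CCN(C)C)c1cccc(F)c1N1CCN(C(=O)[C@@H]2CN(C(C)C)C[C@H]2c2cc(F)c(F)c(F)c2)CC1` gives 250 nM in this assay, the higher of the two numbers. Compound 2 `CC(=O)N1C[C@@H](C(=O)N2CCN(c3ccc(C)cc3[C@@H](NC(=O)CCN(C)C)C(C)C)CC2)[C@H](c2ccc(Cl)cc2)C1` gives 7.6 nM in this assay, a far lower number, and the gap between the two lies well beyond the usual scatter of repeated measurements; since the two compounds differ in several places at once, no single change can be credited for it. Compound 3 `CC(C)[C@H](NC(=O)CCN(C)C)c1cccc(F)c1N1CCN(C(=O)[C@@H]2CN(C(C)C)C[C@H]2c2cccc(Cl)c2)CC1` is compound 1 with one change: 3-chlorophenyl in place of 3,4,5-trifluorophenyl on a saturated ring carbon. Going by the values given here, no measured pair shows this change on its own. Compound 2, which also carries a chlorophenyl group on its saturated ring, gives 7.6 nM, which hints that a chlorophenyl group is compatible with lower numbers, though its other differences leave the size of any effect open. A modest step toward a lower number is therefore expected, a 2.5-fold lower number from compound 1 to compound 3 (0.40 log units; beyond the scatter). Compound 3 is estimated at 100 nM, with a range from 30 nM to 400 nM.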

Compound 3, inhibition constant: 370 nM
The estimate for compound 3 lay 3.7-fold (0.57 log units) below the measured number; low and high end bracket the measured number.
By their numbers in this assay, from the lowest: compound 2; then compounds 1 and 3 (each within the scatter of the next).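

In this assay, going by these compounds alone, putting 3-chlorophenyl in place of 3,4,5-trifluorophenyl on this saturated ring carbon gives a 1.5-fold higher number from compound 1 to compound 3 (0.17 log units; within the scatter), the first reading of this change on its own. On the core of compound 1, then, the two groups cannot be told apart at this position, although the entering group has one chlorine where the leaving group has three fluorines, and fewer heavy atoms. Nothing at hand bears on why the two groups read alike.

Still open, going by these compounds, is whether a ring of another kind at this carbon, such as a pyridine ring or a phenyl carrying a methoxy group, would move the number beyond the scatter. Also open, on these data alone, is whether the same change would read alike on the core of compound 2, which differs in several places.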